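Swapping a short amine chain for an aromatic ring

This account rests on a few compounds, and the source may have more. Where it says the series, first, only, none or still open, it means among the compounds named here.

Compound 1 `O=C(c1cccc(Nc2ncc(F)c(Nc3ccc(F)cc3)n2)c1)N1CCCCC1`: 13200 nM
Compound 2 `Cn1ccnc1NC(=O)c1cccc(Nc2ncc(F)c(Nc3ccc(F)cc3)n2)c1`: 10100 nM
Compound 3 `CN(C)CC(=O)Nc1cccc(Nc2ncc(F)c(Nc3ccc(F)cc3)n2)c1`: 1180 nM

In a functional assay on A549 cells (Homo sapiens) for antiproliferative activity, read by sulforhodamine B assay, with a stated time of 3 days (on this read-out higher numbers stand for weaker inhibition of growth and lower numbers for stronger inhibition of growth), compound 3 gives the lowest number of the three, with an 11-fold lower number from compound 1 to compound 3 (1.05 log units; beyond the scatter) and an 8.6-fold lower number from compound 2 to compound 3 (0.93 log units; beyond the scatter), both beyond the scatter. Compound 4 `CN(C)c1ccc(C(=O)Nc2cccc(Nc3ncc(F)c(Nc4ccc(F)cc4)n3)c2)cc1` keeps the shared core of compound 3 and changes only the group on the carbonyl carbon: 4-(dimethylamino)phenyl in place of (dimethylamino)methyl on a carbonyl carbon. Among the measured compounds shown here, no measured step tests a chain against a ring at this position; the only change confined to the carbonyl carbon, a 1.3-fold lower number from compound 1 to compound 2 (0.12 log units; within the scatter), stayed within the scatter, while the large steps to compound 3 carried the chain in. Removing that chain is expected to cost part of the gain, so a moderate rise, a 3.4-fold higher number from compound 3 to compound 4 (0.53 log units; beyond the scatter), is expected. Compound 4 is estimated at 4000 nM, within 1000 nM to 15000 nM.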

Compound 4, concentration for 50% growth inhibition: > 10000 nM
Compound 4: no number, only a limit; the forecaster's own chance of this, stated with the estimate: 5%; middle value at least 2.5-fold (0.39 log units) from the limit.
By their numbers in this assay, from the lowest: compound 3; then compounds 2 and 1 (each within the scatter of the next).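

Among the compounds shown here, at the carbonyl carbon, this is the first direct test of a ring against a chain: 4-(dimethylamino)phenyl in place of (dimethylamino)methyl gives an at least 8.4-fold higher number from compound 3 to compound 4 (0.92 log units; beyond the scatter) in this assay. Compound 4 has only a limit, not a number: the limit of > 10000 nM in this assay, at which 1 of the 4 values shown sits.

Keeping the dimethylamino group on a phenyl ring therefore does not preserve the growth inhibition seen with compound 3. Still open, going by these compounds, is whether a longer chain, such as 2-(dimethylamino)ethyl, or a ring amine, such as piperidin-1-ylmethyl, would preserve it at this carbonyl carbon.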